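A few compounds are considered here, and "the series" means these few. Any claim that something is new, unique, unknown or untested is made for them only; others in the source may bear on it.

Measured so far in a functional assay on Hs-578T cells (Homo sapiens) for antiproliferative activity, read by sulforhodamine B assay, with a stated time of 48 h; on this read-out higher numbers stand for weaker inhibition of growth and lower numbers for stronger inhibition of growth:
compound 1 `Nc1nn(C(=O)Nc2ccc(Cc3ccccc3)cc2)c2ccccc12`: 71800 nM
compound 2 `Nc1nn(C(=O)Nc2ccc(Cc3ccccc3)cc2)c2ccc(Cl)cc12`: 41700 nM

Among the measured compounds shown here, compound 2 gives the lowest of the two numbers, though the only step, a 1.7-fold lower number from compound 1 to compound 2 (0.24 log units; within the scatter), lies within the scatter. Compound 3 `Nc1ccc2c(c1)c(N)nn2C(=O)Nc1ccc(Cc2ccccc2)cc1` carries the change (amino in place of chloro on an aromatic carbon). For the measured compounds named here, no measured step swaps chloro for amino at this position, so the bearing of a 1.7-fold lower number from compound 1 to compound 2 (0.24 log units; within the scatter) is indirect and, being within the scatter, points to no shift beyond the scatter for compound 3 in this assay. Compound 3 is therefore expected near 60000 nM, between 25000 nM and 150000 nM. The expected step is a 1.4-fold higher number from compound 2 to compound 3 (0.16 log units; within the scatter).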

Compound 3, concentration for total growth inhibition: 43000 nM
Beside the measured number, compound 3's estimate is 1.4-fold (0.14 log units) above it, within the range that was stated.
By their numbers in this assay, from the lowest: compounds 2, 3 and 1 (each within the scatter of the next).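

In this assay, amino in place of chloro on this aromatic carbon gives a 1.0-fold higher number from compound 2 to compound 3 (0.01 log units; within the scatter), and amino in place of hydrogen gives a 1.7-fold lower number from compound 1 to compound 3 (0.22 log units; within the scatter). Hydrogen, chloro and amino at this position thus show no separation beyond the scatter, even though amino adds a hydrogen-bond donor and a hydrogen-bond acceptor that chloro lacks.

Open, going by these compounds, is whether a larger group here, such as a carboxylic acid, a methoxy group or a longer alkyl chain, would move the number beyond the scatter. No evidence on the cause of these results is available.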